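This account rests on a few compounds, and the source may have more. Where it says the series, first, only, none or still open, it means among the compounds named here.

Working notes on the series. The shared core runs unchanged through the set; all variation sits on the amine nitrogen whose other neighbour is a double-bonded ring carbon. Compound 1 `Cc1ccc(NC2=CC(=O)c3c(nc4n3[C@H]3OC[C@@H](O)[C@H]3OC4)C2=O)cc1C` carries (3,4-dimethylphenyl)amino there, and in a functional assay on MGC-803 cells (Homo sapiens) for inhibition, read by sulforhodamine B assay (a higher number here means a weaker inhibitor, a lower number a stronger inhibitor), compound 1 gives 1050 nM. Compound 2 `O=C1C(N2CCCCC2)=CC(=O)c2c1nc1n2[C@H]2OC[C@@H](O)[C@H]2OC1` has piperidin-1-yl in that place; in this assay compound 2 reaches only the limit of the assay, > 4000 nM, and no number. Compound 3 `CCOc1ccccc1NC1=CC(=O)c2c(nc3n2[C@H]2OC[C@@H](O)[C@H]2OC3)C1=O` has 2-ethoxyphenyl on the amine nitrogen; in this assay compound 3 gives 2830 nM, the highest of the two numbers shown, with compound 1 the nearest: a 2.7-fold higher number from compound 1 to compound 3 (0.43 log units; beyond the scatter). The other measured step, an at least 3.8-fold higher number from compound 1 to compound 2 (0.58 log units; beyond the scatter), ends at the limit (the limit of > 4000 nM in this assay, at which 1 of the 3 values shown sits).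

Compound 4 `O=C1C(NCc2ccccc2)=CC(=O)c2c1nc1n2[C@H]2OC[C@@H](O)[C@H]2OC1` follows from compound 3 by one change: benzyl in place of 2-ethoxyphenyl on an amine nitrogen. Neither measured step matches it directly. The step from compound 1 to compound 3 shows that swapping one aryl group for another on the amine nitrogen moves the number modestly; the step from compound 1 to compound 2 shows that a saturated amine without an aromatic ring passes the limit. Benzyl keeps an aromatic ring but is not an aryl amine, so a weaker inhibitor than compound 3 is expected in this assay, a step of a 1.2-fold higher number from compound 3 to compound 4 (0.09 log units; within the scatter), with a real chance of a limit. Compound 4 is estimated at 3500 nM, between 1500 nM and 8000 nM.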

Compound 4, half-maximal inhibitory concentration: 3490 nM
Compound 4: the middle estimate sits 1.0-fold (0.00 log units) above what was measured; the range from low to high includes it.
By their numbers in this assay, from the lowest: compound 1; then compounds 3 and 4 (each within the scatter of the next). At a limit, above all of these: compound 2.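

In this assay, benzyl in place of 2-ethoxyphenyl on the amine nitrogen gives a 1.2-fold higher number from compound 3 to compound 4 (0.09 log units; within the scatter), so the two groups cannot be told apart here. The gap to the 3,4-dimethylphenyl group is real, with a 3.3-fold higher number from compound 1 to compound 4 (0.52 log units; beyond the scatter), which means that a ring of carbon only on this nitrogen does not by itself set the number: compounds 3 and 4 both carry one and still stand apart from compound 1. Compound 2 gives > 4000 nM, which is a limit of the assay and not a number. Measured from that limit, the step is an at least 1.1-fold lower number from compound 2 to compound 4 (0.05 log units; that floor lies within the scatter), so the piperidin-1-yl group cannot be ranked against benzyl.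

Going by these compounds, what remains open is whether the 3,4-dimethyl pattern would hold its advantage on a benzyl ring, or whether it depends on the ring sitting directly on the nitrogen. A longer chain such as phenethyl, an unsubstituted phenyl ring and a small open-chain amine such as diethylamino would each test a different part of this question.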